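Hydroxy in Place of Carbamoyl on the Aromatic Ring

The compounds below may be only part of what the source reports. "The series", "measured", "known", "first", "only" and "open" are said of these compounds alone.

Of the compounds shown here, three sharing one core have been measured in a functional assay on NCI-H460 cells (Homo sapiens) for antiproliferative activity, with a stated time of 72 h; on this read-out higher numbers stand for weaker inhibition and lower numbers for stronger inhibition. Compound 1 `C=CC[C@H]1C[C@]2([C@H](C)Cc3ccc(OC)cc3)OCOC2=CC1=O` gives 120 nM in this assay. Compound 2 `C=CC[C@H]1C[C@]2(C(C)Cc3ccc(OCC)cc3)OCOC2=CC1=O` gives 280 nM. Compound 3 `C=CC[C@H]1C[C@]2([C@@H](C)Cc3ccc(OC)c(C(N)=O)c3)OCOC2=CC1=O` gives 66 nM. The numbers of compound 3 and compound 1 lie within the scatter of each other, so nothing separates them with confidence; the number of compound 2 stands beyond the scatter above that of compound 3, so compound 2 is the weaker of those two. No two of the measured compounds differ in only one place, so no single step can be read off from them.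

Compound 4 `C=CC[C@H]1C[C@]2([C@@H](C)Cc3ccc(OC)c(O)c3)OCOC2=CC1=O` has not yet been measured. It differs from compound 3 in one place: hydroxy in place of carbamoyl on an aromatic carbon. Among the measured compounds there is no change of this kind to lean on, so the expectation rests on the structural change alone. The step from compound 3 to compound 4 is expected to be small, a 1.5-fold higher number from compound 3 to compound 4 (0.18 log units; within the scatter), and not clearly beyond the scatter in either direction. For compound 4 the estimated value in this assay is 100 nM, with a range from 40 nM to 250 nM.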

Compound 4, half-maximal inhibitory concentration: 80 nM
For compound 4 the middle estimate is 1.3-fold (0.10 log units) above the measured one; measured number inside the range.
By their numbers in this assay, from the lowest: compounds 3, 4 and 1 (each within the scatter of the next); then compound 2.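

Replacing carbamoyl with hydroxy on this aromatic carbon, ortho to a methoxy group, gives in this assay a step of a 1.2-fold higher number from compound 3 to compound 4 (0.08 log units; within the scatter), so the two compounds cannot be told apart on this read-out. Among these compounds, this is the first comparison in the set that changes one place only, and it shows that a group of 3 heavy atoms at this position can give way to a group of 1 heavy atom with no clear change in the number. Both groups count 1 hydrogen-bond donor and 1 hydrogen-bond acceptor, so the step leaves those counts as they were, and no measurement at hand bears on why the number holds.

Still open, going by these compounds, is whether the number in this assay would hold with an amine, a carboxylic acid or a longer ether chain on this aromatic carbon, groups that would show how much variety the position accepts. Also open, on these data alone, is whether the same exchange of carbamoyl for hydroxy would give so small a step on other cell lines, since this single pair speaks for one assay only.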